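This account rests on a few compounds, and the source may have more. Where it says the series, first, only, none or still open, it means among the compounds named here.

Working notes on the series. The shared core is an ester of a protected amino acid bearing a carbamate, shown for compound 2 as `COc1ccc(COC(=O)[C@H](CC(=O)OC2CCC2)NC(=O)OC(C)(C)C)cc1`. Within the data shown here, in a functional assay on IMR-32 cells for inhibition of Voltage-dependent N-type calcium channel subunit alpha-1B (Homo sapiens), read by calcium flux (a lower number here means a stronger inhibitor, a higher number a weaker inhibitor), compound 2 gives 15000 nM, the highest of the two numbers so far. The other measured compound is compound 1, `COc1ccc(CNC(=O)[C@H](CSCC2CCCCC2)NC(=O)OC(C)(C)C)cc1`, which differs from compound 2 in more than one place; in this assay compound 1 gives 610 nM, and the two values differ by a gap beyond the usual scatter, so nothing more can be read from that pair.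

The next compound is compound 3, `COc1ccc(COC(=O)[C@H](CC(=O)OC2CCCCCC2)NC(=O)OC(C)(C)C)cc1`, which keeps everything of compound 2 except one change: cycloheptyl in place of cyclobutyl on an oxygen next to a carbonyl group. Among the measured compounds shown here, no measured pair shows the effect of ring size at this position, so the step is expected to be modest, if anything toward a lower number, and it may well stay within the scatter. For compound 3 in this assay the expected step from compound 2 is a 1.9-fold lower number from compound 2 to compound 3 (0.27 log units; within the scatter), giving an estimate of 8000 nM, with a range from 2500 nM to 25000 nM.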

Compound 3, half-maximal inhibitory concentration: 2600 nM
Compound 3: middle estimate off by 3.1-fold (0.49 log units), on the high side; measured number inside the range.
By their numbers in this assay, from the lowest: compound 1; then compound 3; then compound 2.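

In this assay the step of a 5.8-fold lower number from compound 2 to compound 3 (0.76 log units; beyond the scatter) shows that this position responds to the group on the oxygen, which the earlier pair, differing in more than one place, could not show. With the rest of the structure unchanged, cycloheptyl gives the lower number of the two rings, but one pair of rings fixes no trend with ring size. Nothing at hand accounts for the direction or size of this step.

On these data alone, it remains open whether cyclopentyl, cyclohexyl or cyclooctyl would fall on a steady progression with cyclobutyl and cycloheptyl, or whether a ring is needed at all compared with an open hexyl chain. Also open, as far as these compounds go, is how an amine or a carboxylic acid on the cycloheptyl ring would alter the number.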